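This account rests on a few compounds, and the source may have more. Where it says the series, first, only, none or still open, it means among the compounds named here.

The series shares a single core, seen in compound 1 `C/C=C/C(=O)Nc1c(C(O)(C(F)(F)F)C(F)(F)F)ccc2ccccc12`, and its members differ only in the group carried on a carbonyl carbon whose other neighbour is an amide-type nitrogen. For the measured compounds named here, in an assay on LtK cells with ATP-sensitive inward rectifier potassium channel 11 (Homo sapiens) as the target (on this read-out higher numbers stand for an effect only at larger amounts of compound and lower numbers for an effect already at smaller amounts), compound 1 gives 72 nM, the lowest of the three numbers known so far. Compound 2 `O=C(Nc1c(C(O)(C(F)(F)F)C(F)(F)F)ccc2ccccc12)C1CC1` gives 751 nM in this assay, and compound 3 `O=C(Nc1ccc(Cl)cc1)Nc1c(C(O)(C(F)(F)F)C(F)(F)F)ccc2ccccc12` gives 276 nM. Both measured steps at this position go upward: a 10-fold higher number from compound 1 to compound 2 (1.02 log units; beyond the scatter) and a 3.8-fold higher number from compound 1 to compound 3 (0.58 log units; beyond the scatter). For the remaining pair, a 2.7-fold lower number from compound 2 to compound 3 (0.43 log units; beyond the scatter).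

Compound 4 `CC(C)OC(=O)Nc1c(C(O)(C(F)(F)F)C(F)(F)F)ccc2ccccc12` has not yet been measured. Its difference from compound 1 is isopropoxy in place of prop-1-en-1-yl on a carbonyl carbon, at the same carbonyl carbon where the two measured steps occurred. Both replacements of the prop-1-en-1-yl group examined so far raised the number in this assay, one by a large and one by a modest margin, and no change at this position has yet given a lower number. Compound 4 is therefore expected to move upward as well, the expected step being a 4.2-fold higher number from compound 1 to compound 4 (0.62 log units; beyond the scatter). For compound 4 the value in this assay is estimated at 300 nM, with a range from 100 nM to 900 nM.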

Compound 4, half-maximal effective concentration: 1160 nM
Compound 4: middle estimate off by 3.9-fold (0.59 log units), on the low side; the measured number lies above the stated range.
By their numbers in this assay, from the lowest: compound 1; then compound 3; then compounds 2 and 4 (each within the scatter of the next).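

In this assay, isopropoxy in place of prop-1-en-1-yl on the carbonyl carbon is a large step (a 16-fold higher number from compound 1 to compound 4 (1.21 log units; beyond the scatter)), so this position now holds three replacements that all give higher numbers than compound 1, and none of the three matches it. Isopropoxy also stands apart from (4-chlorophenyl)amino (a 4.2-fold higher number from compound 3 to compound 4 (0.62 log units; beyond the scatter)), but it cannot be told apart from cyclopropyl (a 1.5-fold higher number from compound 2 to compound 4 (0.19 log units; within the scatter)), which is within the scatter, so an open chain entering through oxygen and a small ring end up at the same level. Nothing available here bears on why the groups fall in this order.

From the compounds shown here alone, how a plain propyl chain on this carbonyl carbon would compare with compound 1 remains open, and with it whether the double bond of prop-1-en-1-yl matters for the low number. Going by these compounds, it is equally open whether a methoxy group or a dimethylamino group at the same carbonyl carbon would fall with compound 4 or with compound 3.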